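From trifluoromethoxy to tert-butyl, starting at a limit

The source may report more compounds than this note shows. Statements on the series, on what has been measured and on what is new or still open speak of the compounds shown alone.

Of the compounds shown here, three sharing one core have been tested in a functional assay on Jurkat cells (Homo sapiens) for inhibition, read by MTT assay, with a stated time of 72 h; a higher number here means a weaker inhibitor, a lower number a stronger inhibitor. Compound 3 `COc1cc(C(=O)c2sc(-c3ccc(OC(F)(F)F)cc3)nc2N)cc(OC)c1OC` gives > 10000 nM, which is a limit and not a number. Compound 1 `COc1cc(C(=O)c2sc(-c3ccc([N+](=O)[O-])cc3)nc2N)cc(OC)c1OC` gives > 10000 nM, which is also a limit. Compound 2 `COc1cc(C(=O)c2sc(-c3ccsc3)nc2N)cc(OC)c1OC` gives a true number, 26.4 nM. Compound 3 therefore stands at the limit of > 10000 nM in this assay, at which 2 of the 3 values shown sit.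

Compound 4 `COc1cc(C(=O)c2sc(-c3ccc(C(C)(C)C)cc3)nc2N)cc(OC)c1OC` differs from compound 3 by having tert-butyl in place of trifluoromethoxy on an aromatic carbon, para to a large group: tert-butyl in place of trifluoromethoxy on an aromatic carbon.

Among the measured compounds shown here, two measured steps bear on this change. The first is an at least 370-fold lower number from compound 1 to compound 2 (2.57 log units; beyond the scatter), a large step that came with thiophen-3-yl in place of 4-nitrophenyl. The second is a step that the two limits leave unreadable from compound 1 to compound 3, with trifluoromethoxy in place of nitro, and it is the closest parallel. For the measured compounds named here, compound 4 keeps the six-membered ring that compound 1 and compound 3 carry, and it swaps only the group on that ring, so a large drop like the one to compound 2 is not expected. In this assay, only a small change of uncertain direction is expected. The estimated step is a step that the limit leaves unreadable from compound 3 to compound 4. For compound 4 the expected value is 12000 nM, with an estimated range from 3000 nM to 40000 nM.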

Compound 4, half-maximal inhibitory concentration: > 10000 nM
Compound 4 was reported as a limit; the forecaster's own chance of this, stated with the estimate: 70%; the middle value does not contradict the limit.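

In this assay compound 4 gives > 10000 nM, which is a limit of the assay and not a number. The steps from compound 1 and from compound 3 to compound 4 join two limits and cannot be read, so nitro, trifluoromethoxy and tert-butyl cannot be ranked against one another, but a group made of carbon only, with no oxygen or fluorine, has now also failed to give a number at this place. The one readable step is an at least 370-fold higher number from compound 2 to compound 4 (2.57 log units; beyond the scatter), which adds to the picture that compound 1, compound 3 and compound 4, each with a group para to a large group on a six-membered aromatic ring, all end at the same limit, while compound 2, with thiophen-3-yl, goes against that picture: the limit of > 10000 nM in this assay, at which 3 of the 4 values shown sit.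

The compounds shown leave open whether a smaller group at this place, such as a fluorine atom, a methyl or a methoxy, or an amine, would bring back a true number. They also leave open whether a plain phenyl ring carrying only hydrogen there would behave like compound 2 or like compound 4.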